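The compounds below may be only part of what the source reports. "The series", "measured", "known", "first", "only" and "open" are said of these compounds alone.

Measured so far:
Compound 1 `COc1ccc(CNc2nc3cc(N)cc(N)c3nc2-c2ccccc2)cc1OC` gives 13500 nM in a functional assay on BT-549 cells (Homo sapiens) for inhibition, read by sulforhodamine B assay, with a stated time of 48 h; a higher number here means a weaker inhibitor of growth, a lower number a stronger inhibitor of growth.
Compound 2 `CCOC(=O)[C@H](CCC(=O)O)NC(=O)c1ccc(Sc2nc3cc(N)cc(N)c3nc2-c2ccccc2)cc1` gives 6310 nM in this assay.
Compound 3 `CCOC(=O)[C@H](CCC(=O)O)NC(=O)c1ccc(Oc2nc3cc(N)cc(N)c3nc2-c2ccccc2)cc1` gives 33900 nM in this assay.

Among these three numbers compound 1 stands second highest: compound 2 sits lower by a margin beyond the usual scatter, and compound 3 sits higher, also beyond it. Compound 4 `COc1ccc(CNc2nc3cc(N)cc(N)c3nc2-c2ccccc2)cc1` differs from compound 1 in one place, (hydrogen in place of methoxy on an aromatic carbon). Among the compounds with values here, no pair of measured compounds isolates this change, and compounds 2 and 3 differ from compound 1 in several places at once, so they give no guide to its size. In this assay the step is expected to be small, a 1.1-fold higher number from compound 1 to compound 4 (0.05 log units; within the scatter), with no direction beyond the scatter. Compound 4 is therefore estimated at 15000 nM, with a range from 6000 nM to 40000 nM.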

Compound 4, concentration for 50% growth inhibition: 6460 nM
Compound 4: the middle estimate sits 2.3-fold (0.37 log units) above what was measured, within the range that was stated.
By their numbers in this assay, from the lowest: compounds 2 and 4 (each within the scatter of the next); then compound 1; then compound 3.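

In this assay, going from 3,4-dimethoxyphenyl to 4-methoxyphenyl gives a 2.1-fold lower number from compound 1 to compound 4 (0.32 log units; beyond the scatter). This shows that the methoxy at this position is not required for growth inhibition on this core, and that hydrogen there gives the lower number of the two. Nothing measured here explains this step.

This single pair leaves open whether a hydroxyl, a fluorine or an amine at the same position would move the number further. It also leaves open how the number would respond if the remaining methoxy gave way to hydrogen.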